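The source may report more compounds than this note shows. Statements on the series, on what has been measured and on what is new or still open speak of the compounds shown alone.

Measured values in a physicochemical assay for lipophilicity, read by HPLC, measured as chromatographic lipophilicity, at pH 7.4; a higher number here means a more lipophilic compound, a lower number a more polar compound:
- compound 1 `COc1cccc(NC(=O)c2nnn(Cc3ccncc3)c2N)c1`: 1.4
- compound 2 `COc1cccc(NC(=O)c2nnn(Cc3ccc(C(C)C)cc3)c2N)c1`: 3.4
- compound 3 `COc1cccc(NC(=O)c2nnn(Cc3ccccc3)c2N)c1`: 2.6

Compound 3, at 2.6, holds the middle place of the three numbers, and both gaps to it lie beyond the scatter. Compound 4 `COc1cccc(NC(=O)c2nnn(Cc3cc(C)on3)c2N)c1` carries 5-methyl-1,2-oxazol-3-yl in place of phenyl on a saturated chain carbon bound to an aromatic nitrogen. For the measured compounds named here, no measured compound carries this group. The closest guide is the large step at the same place, a number 1.20 log units higher from compound 1 to compound 3 (beyond the scatter), which links pyridin-4-yl and phenyl. The modest step of a number 0.80 log units lower from compound 2 to compound 3 (beyond the scatter) is a weaker guide, since it concerns hydrogen in place of isopropyl on an aromatic carbon, yet there the alkyl-bearing compound stands higher. A fall in this assay beyond the scatter is therefore expected, somewhat smaller than the pyridin-4-yl gap. The expected size is a number 0.80 log units lower from compound 3 to compound 4 (beyond the scatter). For compound 4 the estimated value is 1.8, with an expected range of 1.4 to 2.2.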

Compound 4, distribution coefficient: 2
Compound 4: the middle estimate sits 0.20 log units below what was measured; the measured number falls inside the stated range.
By their numbers in this assay, from the lowest: compound 1; then compound 4; then compound 3; then compound 2.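

At the place on a saturated chain carbon bound to an aromatic nitrogen, a five-membered aromatic ring now joins the six-membered rings, and in this assay 5-methyl-1,2-oxazol-3-yl lands inside their span: a number 0.60 log units lower from compound 3 to compound 4 (beyond the scatter), a number 1.40 log units lower from compound 2 to compound 4 (beyond the scatter) and a number 0.60 log units higher from compound 1 to compound 4 (beyond the scatter). The exchange of phenyl for 5-methyl-1,2-oxazol-3-yl keeps the heavy-atom count and still moves the number beyond the scatter, so heavy-atom count alone does not set the reading across compound 3 and compound 4, and all four compounds stand apart at this one place. Nothing measured here gives a reason for these differences.

On these data alone, how much of the step belongs to the methyl group and how much to the ring itself stays open. So does the reading at this place for an amine, a carboxylic acid or a longer chain between the ring and the aromatic nitrogen.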